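A few compounds are considered here, and "the series" means these few. Any claim that something is new, unique, unknown or untested is made for them only; others in the source may bear on it.

Compound 1 `CCCCCCNc1nc(SCc2ccc(C(F)(F)F)cc2)nc2ccccc12` gives 23900 nM in a functional assay on HGC-27 cells (Homo sapiens) for cytotoxicity, read by MTT assay, with a stated time of 72 h; on this read-out higher numbers stand for weaker inhibition and lower numbers for stronger inhibition. Compound 2 `FC(F)(F)c1ccc(CSc2nc(N3CCCCC3)c3ccccc3n2)cc1` reaches only the limit > 50000 nM in this assay. Compound 3 `CCOc1ccccc1Nc1nc(SCc2ccc(C(F)(F)F)cc2)nc2ccccc12` likewise reaches only the limit > 50000 nM in this assay.

Where compound 3 stands is set by the limit of > 50000 nM in this assay, at which 2 of the 3 values shown sit. Compound 4 `Cc1ccccc1Nc1nc(SCc2ccc(C(F)(F)F)cc2)nc2ccccc12` differs from compound 3 by methyl in place of ethoxy on an aromatic carbon. Among the compounds with values here, no measured step covers this change: the steps of an at least 2.0-fold higher number from compound 1 to compound 3 (0.32 log units; beyond the scatter) and a step that the two limits leave unreadable from compound 2 to compound 3 alter the whole amine rather than a substituent on the phenyl ring, and both end at the limit, so the size of the step that the two limits leave unreadable from compound 2 to compound 3 cannot be read. Compound 4 is therefore expected to stay weak, at an estimated 45000 nM with a range from 15000 nM to 100000 nM. This estimate means an expected step of an at least 1.1-fold lower number from compound 3 to compound 4 (0.04 log units; that floor lies within the scatter).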

Compound 4, half-maximal inhibitory concentration: 27500 nM
The estimate for compound 4 lay 1.6-fold (0.21 log units) above the measured number; low and high end bracket the measured number.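

Methyl in place of ethoxy on the phenyl ring gives a readable number in this assay instead of a limit, an at least 1.8-fold lower number from compound 3 to compound 4 (0.25 log units; that floor lies within the scatter), and the same compound stands against the piperidin-1-yl group with an at least 1.8-fold lower number from compound 2 to compound 4 (0.25 log units; that floor lies within the scatter). Both steps start from a limit, so their true size stays unknown: the limit of > 50000 nM in this assay, at which 2 of the 4 values shown sit.

With the hexylamino group, the (2-methylphenyl)amino group sits level, a 1.2-fold higher number from compound 1 to compound 4 (0.06 log units; within the scatter).

The compounds shown leave open how a methoxy or a chlorine at this ring carbon would read. They also leave open whether a phenylamino group without any substituent would give a number or a limit.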